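A few compounds are considered here, and "the series" means these few. Any claim that something is new, unique, unknown or untested is made for them only; others in the source may bear on it.

Measured so far in a physicochemical assay for acid dissociation:
compound 1, `COc1cccc(Oc2ccc3c(NCCCNCc4cc(F)ccc4OC)ccnc3c2)c1`, gives 9.28
compound 2, `COc1ccc(F)cc1CNCCCNc1ccnc2cc(Cc3ccc(F)cc3)ccc12`, gives 9.47
compound 3, `COc1ccc(F)cc1CNCCCNc1ccnc2cc(Cc3ccc(C#N)cc3)ccc12`, gives 9.47

Compound 3 stands level with compound 2 at the digits shown, the nearest of the three to it: no change at the digits printed from compound 2 to compound 3 (within the scatter). The furthest is compound 1: a number 0.19 log units higher from compound 1 to compound 3 (within the scatter). All three numbers therefore sit within the scatter of one another, and no order among them can be read from this assay.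

Compound 4, `COc1ccc(F)cc1CNCCCNc1ccnc2cc(-c3cccc4ccccc34)ccc12`, has not yet been measured in this assay. Among the measured compounds shown here, it differs from compound 3 at the aromatic carbon of the shared core that was varied in every step so far: naphthalen-1-yl in place of 4-cyanobenzyl on an aromatic carbon.

For the measured compounds named here, the steps that bear on this change are the three measured ones at the same place: a number 0.19 log units higher from compound 1 to compound 2 (within the scatter), a number 0.19 log units higher from compound 1 to compound 3 (within the scatter) and no change at the digits printed from compound 2 to compound 3 (within the scatter). Each lies within the scatter, whether the group at that carbon was 3-methoxyphenoxy, 4-fluorobenzyl or 4-cyanobenzyl. The basic centre measured here is remote from this carbon in all three compounds and remains so in compound 4. No step beyond the scatter is expected: a number 0.02 log units lower from compound 3 to compound 4 (within the scatter).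

Compound 4 is thus estimated at 9.45, with a range from 9.15 to 9.75.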

Compound 4, acid dissociation constant: 9.47
The estimate for compound 4 lay 0.02 log units below the measured number, within the range that was stated.
By their numbers in this assay, from the lowest: compounds 1, 2, 3 and 4 (each within the scatter of the next).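

In this assay the series now includes a group joined directly to this aromatic carbon and carrying two six-membered aromatic rings of carbon only, and the read-out stays within the scatter across the replacement: no change at the digits printed from compound 3 to compound 4 (within the scatter), no change at the digits printed from compound 2 to compound 4 (within the scatter) and a number 0.19 log units higher from compound 1 to compound 4 (within the scatter). The earlier groups, 3-methoxyphenoxy, 4-fluorobenzyl and 4-cyanobenzyl, each held a single six-membered aromatic ring reached through a linking atom, so neither the direct attachment, the second ring nor the absence of the hydrogen-bond acceptor of 4-cyanobenzyl gives a step beyond the scatter in these four compounds. No measurement accompanies this result that would account for it.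

From the compounds shown here alone, all four compounds place an aromatic ring system at this carbon and share the same side chain, so it remains open whether a group of another kind there, such as a carboxylic acid or a piperidine amine, would give a step beyond the scatter. Also open, going by these compounds, is how the number responds to a longer chain between the two nitrogens of that side chain, or to replacing the methoxy group on its fluorinated ring.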